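Removing the ring methyl from the hydrazone series

The compounds below may be only part of what the source reports. "The series", "measured", "known", "first", "only" and "open" are said of these compounds alone.

Three compounds on the shared core have numbers in a functional assay, read by spectrophotometry, with a stated time of 3 min; on this read-out higher numbers stand for weaker inhibition and lower numbers for stronger inhibition. Compound 1 `Cc1ccc2[nH]c(=O)c(/C=N/Nc3ccc([N+](=O)[O-])cc3)cc2c1` gives 8250 nM in this assay. Compound 2 `N/N=C/c1cc2ccccc2[nH]c1=O` gives 20600 nM in this assay. Compound 3 `O=C(O)c1ccc(/N=C/c2cc3ccccc3[nH]c2=O)cc1` gives 438000 nM in this assay. Compound 1 thus stands at the lowest number of the three, with compound 2 at a higher number that lies beyond the usual scatter and compound 3 at a far higher number, also beyond the scatter. No two of these compounds differ in a single place, so no single change can be read from them.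

Compound 4 `O=c1[nH]c2ccccc2cc1/C=N/Nc1ccc([N+](=O)[O-])cc1` is not yet measured in this assay. Against compound 1 the change is hydrogen in place of methyl on an aromatic carbon. Going by the values given here, nothing among the measured compounds speaks to this change. A small step is expected, most likely none beyond the scatter, with a slight lean toward a higher number; the expected step from compound 1 to compound 4 is a 1.5-fold higher number from compound 1 to compound 4 (0.16 log units; within the scatter). For compound 4 the estimate in this assay is 12000 nM, with a range from 5000 nM to 30000 nM.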

Compound 4, half-maximal inhibitory concentration: 11400 nM
Compound 4: the middle estimate sits 1.1-fold (0.02 log units) above what was measured; the range from low to high includes it.
By their numbers in this assay, from the lowest: compounds 1, 4 and 2 (each within the scatter of the next, the first and the last beyond it); then compound 3.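

Hydrogen in place of methyl on an aromatic carbon gives a 1.4-fold higher number from compound 1 to compound 4 (0.14 log units; within the scatter) in this assay and lies within the scatter. This pair is the only one in the series that differs in a single place, and it shows that, with the rest of compound 1 held fixed, the methyl can be lost from this position without a step that can be told from the scatter. No information on hand accounts for this result.

From the compounds shown here alone, whether a larger or different group on this aromatic carbon, such as ethyl, methoxy, chlorine, an amine or a carboxylic acid, would give a step beyond the scatter remains open. One pair also leaves open whether the same change would give a similar step with other groups on the rest of the shared core.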